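Moving a methyl on the cyclopropyl of compound 2

This account rests on a few compounds, and the source may have more. Where it says the series, first, only, none or still open, it means among the compounds named here.

Of the compounds shown here, three have been measured so far in an ADME assay on microsomes from liver (Rattus norvegicus) for pharmacokinetics (a higher number here means faster removal of the compound, a lower number slower removal), and only one of them gives a true number. Compound 1 (`Cn1cc(-c2ncc(C#N)c(N3C[C@@H]4C[C@H]3CN4S(=O)(=O)C3CC3)n2)cn1`) reads < 36 mL/min/kg there, which is a limit of the assay and not a number. Compound 3 (`Cn1cc(-c2ncc(C#N)c(N3C[C@@H]4C[C@H]3CN4C(=O)C3CC3)n2)cn1`) reads < 36 mL/min/kg there, again a limit. Within the data shown here, compound 2 (`C[C@@H]1C[C@H]1C(=O)N1CCN(c2nc(-c3cnn(C)c3)ncc2C#N)C[C@H]1C`) gives 54 mL/min/kg in this assay and so stands as the sole numerical value in the set.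

Compound 4 (`C[C@@H]1CN(c2nc(-c3cnn(C)c3)ncc2C#N)CCN1C(=O)C1(C)CC1`) has the same atoms as compound 2, joined differently (1-methylcyclopropyl in place of 2-methylcyclopropyl on a carbonyl carbon), with 1-methylcyclopropyl in place of 2-methylcyclopropyl on a carbonyl carbon. Among the measured compounds shown here, the only measured step is a step that the two limits leave unreadable from compound 1 to compound 3 and it offers no size to carry over. The shared floor of those two compounds, (the limit of < 36 mL/min/kg in this assay, at which 2 of the 3 values shown sit), adds no measured guide to this change either.

The expectation therefore rests on compound 2 alone, at 54 mL/min/kg, with no shift beyond the usual scatter expected in either direction in this assay for this change. The expected step is a 1.1-fold lower number from compound 2 to compound 4 (0.03 log units; within the scatter) and it stays within that scatter. For compound 4 the estimated clearance is 50 mL/min/kg, with an expected range from 30 mL/min/kg to 85 mL/min/kg.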

Compound 4, clearance: < 36 mL/min/kg
Compound 4: only a limit was reported; the forecaster's own chance of this, stated with the estimate: 20%; at least 1.3-fold (0.14 log units) between middle value and limit.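

In this assay, among these compounds, the exchange of 2-methylcyclopropyl for 1-methylcyclopropyl on a carbonyl carbon gives an at least 1.5-fold lower number from compound 2 to compound 4 (0.17 log units; that floor lies within the scatter), which is the first step in the set that can be given any size, although its floor does not clear the usual scatter. Compound 4 reports a limit and not a number, so the step has a floor but no measured end, and on this floor alone the change cannot be called a real fall in clearance. What the result adds is that a rearrangement of the same atoms in this one group is enough to take the compound from a true number to the floor of the assay, where most of the set now sits: the limit of < 36 mL/min/kg in this assay, at which 3 of the 4 values shown sit.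

Going by these compounds, how far compound 4 really lies from compound 2 stays unknown, and the step from compound 1 to compound 3 still cannot be read, so no size can be compared with this one. On these data alone, it also remains open whether a cyclobutyl or a tert-butyl on the same carbonyl carbon would read like 1-methylcyclopropyl or like 2-methylcyclopropyl.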